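Fluoro to Cyano on the Benzyl Ring: Cytotoxicity Outlook

The source may hold more compounds than are shown below. What is called first, only, known or untested is meant among the compounds shown, and "the series" means these compounds.

Compound 1 `COC(=O)c1ccc(NCc2cncn2Cc2cccc(F)c2)cc1-c1ccccc1` in a toxicity assay on NIH3T3 cells (Mus musculus) for cytotoxicity, read by resazurin assay; a lower number here means that less compound is needed, a higher number that more compound is needed for the effect: > 1000 nM, a limit.
Compound 2 `c1ccc(Cn2cncc2CNc2cccc(-c3ccncc3)c2)cc1` in this assay: > 1000 nM, a limit.

Compound 1 gives no number, only a limit, and so sits where every value shown sits: the limit of > 1000 nM in this assay, at which 2 of the 2 values shown sit. Compound 3 `COC(=O)c1ccc(NCc2cncn2Cc2cccc(C#N)c2)cc1-c1ccccc1` is not yet measured; it differs from compound 1 by cyano in place of fluoro on an aromatic carbon. Among the compounds with values here, no step between measured compounds is available, so for compound 3 in this assay no change beyond the usual scatter is expected, and a limit again seems the most likely outcome. The estimate for compound 3 is 3000 nM, between 1000 nM and 10000 nM, which would mean a step that the limit leaves unreadable from compound 1 to compound 3.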

Compound 3, half-maximal effective concentration: > 10000 nM
Compound 3 gave a limit, no number; the forecaster's own chance of this, stated with the estimate: 85%; middle value at least 3.3-fold (0.52 log units) away from the limit.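

Compound 1 and compound 3 both gave only limits in this assay, so the step between them cannot be read. The compounds shown leave open what concentration of any of them would reach the half-maximal effect, and whether cyano in place of fluoro shifts it at all.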